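The compounds below may be only part of what the source reports. "The series", "measured", "known", "first", "only" and "open" are said of these compounds alone.

Of the compounds shown here, two of a shared core have been measured for how long they survive in the presence of liver enzymes. Compound 1 `c1ccc(-c2ccc(C3=NC(Cn4ccnc4)(c4ccccc4)CO3)cc2)cc1` gives 1.77 h in an ADME assay on microsomes from liver (Homo sapiens) for metabolic stability, read by LC-MS, using NADPH, with a stated time of 60 min, tested at 100 uM; a lower number here means that the compound disappears faster, a higher number that the compound lasts longer. Compound 2 `Fc1ccc(C2(Cn3cncn3)COC(c3ccc(-c4cccc(F)c4)cc3)=N2)cc1` gives 0.985 h in this assay. Compound 2 shows the lower of the two numbers, with compound 1 the nearest, and the gap between them lies within the usual scatter, so the two cannot be told apart on these data. Compound 3 `Fc1ccc(C2(Cn3cncn3)COC(c3ccc(-c4ccccc4F)cc3)=N2)cc1` is the next compound, differing from compound 2 by a single rearrangement: 2-fluorophenyl in place of 3-fluorophenyl on an aromatic carbon. Going by the values given here, nothing measured so far speaks to this kind of change, so no step beyond the scatter is expected in either direction. The half-life of compound 3 is therefore estimated at 1 h, within a range from 0.5 h to 2 h, which amounts to an expected step of a 1.0-fold higher number from compound 2 to compound 3 (0.01 log units; within the scatter).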

Compound 3, half-life: > 2.41 h
Compound 3: no number, only a limit; the forecaster's own chance of this, stated with the estimate: 5%; middle value at least 2.4-fold (0.38 log units) from the limit.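

Exchanging 3-fluorophenyl for 2-fluorophenyl on an aromatic carbon, para to a large group, leaves the atoms the same but joins them differently, and it gives an at least 2.4-fold higher number from compound 2 to compound 3 (0.38 log units; beyond the scatter) in this assay. Going by these compounds alone, this is the first sign that the half-life responds to where the fluorine sits on this ring, which compound 1 and compound 2 could not show, as they differ in more than one place. The entry for compound 3 is a limit and not a number, so the full size of the step stays unknown: the limit of > 2.41 h in this assay, at which 1 of the 3 values shown sits.

The compounds shown leave open what other groups would do at this place, such as a chlorine atom, a methoxy group or an amine. Going by these compounds, whether the same exchange would give a similar step on compound 1 also remains open.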